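Swapping the side chain of compound 1 for a cyclobutyl group

A few compounds are considered here, and "the series" means these few. Any claim that something is new, unique, unknown or untested is made for them only; others in the source may bear on it.

Compound 1, with the structure `CC(C)(CCCCF)[C@H](O)/C=C/[C@H]1COC(=O)N1CCSc1nc(C(=O)O)cs1`, was tested in an assay on isolated protein for agonist activity at prostaglandin E2 receptor EP2 subtype (Homo sapiens) (a higher number here means that more compound is needed for the effect, a lower number that less compound is needed), and gives 5.7 nM. Among the three measured compounds it holds the second highest number: compound 3, `CCCC[C@H](C)C[C@H](O)/C=C/[C@H]1CCC(=O)N1CCSc1nc(C(=O)O)cs1`, gives 0.39 nM, a lower number beyond the usual scatter, while compound 2, `O=C(O)c1csc(SCCN2C(=O)OC[C@@H]2/C=C/[C@@H](O)C2(CCc3ccccc3)CCC2)n1`, gives 160 nM, a higher number also beyond the scatter. Compound 4, `COCCCC1([C@H](O)/C=C/[C@H]2COC(=O)N2CCSc2nc(C(=O)O)cs2)CCC1`, has not yet been measured. It differs from compound 1 in one place: 1-(3-methoxypropyl)cyclobutyl in place of 5-fluoro-1,1-dimethylpentyl on a saturated chain carbon bound to a double-bonded chain carbon and an oxygen on a saturated carbon. For the measured compounds named here, no measured pair shows exactly this change, so the size of the step is uncertain. Compound 2 also carries a cyclobutyl group at that position on the same core and gives 160 nM, which suggests the direction is toward a higher number. Compound 4 is therefore expected to need somewhat more compound than compound 1, with an expected step of a 3.5-fold higher number from compound 1 to compound 4 (0.55 log units; beyond the scatter) in this assay. The estimate for compound 4 is 20 nM, within a range from 4 nM to 100 nM.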

Compound 4, half-maximal effective concentration: 18 nM
Compound 4: middle estimate off by 1.1-fold (0.05 log units), on the high side, and the stated range covers the measured number.
By their numbers in this assay, from the lowest: compound 3; then compound 1; then compound 4; then compound 2.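

In this assay, 1-(3-methoxypropyl)cyclobutyl in place of 5-fluoro-1,1-dimethylpentyl gives only a modest change, a 3.2-fold higher number from compound 1 to compound 4 (0.50 log units; beyond the scatter), so this position accepts a group with a four-membered ring and an oxygen without a large rise in the number. The cyclobutyl ring alone does not set the high number of compound 2: with the ring kept, methoxymethyl in place of phenyl on a saturated chain carbon, two bonds along the chain from a saturated ring carbon, gives an 8.9-fold lower number from compound 2 to compound 4 (0.95 log units; beyond the scatter). What the chain on the ring carries therefore matters here, not only the ring.

The step from compound 1 changes the ring and the oxygen together, and a plain propyl chain or an amine on the cyclobutyl group would be needed to tell their shares apart. No measurement shown here explains why either step has its size.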